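The compounds below may be only part of what the source reports. "The series", "measured", "known", "first", "only" and "open" are said of these compounds alone.

Compound 1 `Cc1c(C(=O)NCc2ccccc2)[n+]([O-])c2ccccc2[n+]1[O-]`, compound 2 `Cc1ccc2c(c1)[n+]([O-])c(C(=O)NCc1ccccc1)c(C)[n+]2[O-]`, compound 3 `COc1ccc2c(c1)[n+]([O-])c(C(=O)NCc1ccccc1)c(C)[n+]2[O-]` and compound 4 `Cc1c(C(=O)NCc2ccccc2)[n+]([O-])c2cc(Cl)ccc2[n+]1[O-]` share one core. In an ADME assay on Vero cells (Chlorocebus sabaeus) for cytotoxicity, read by MTT assay, with a stated time of 72 h (a higher number here means a weaker inhibitor, a lower number a stronger inhibitor), compound 1 gives only a limit of the assay, > 100 ug/mL. In this assay compound 2 likewise gives only a limit, > 100 ug/mL. The step that the two limits leave unreadable from compound 1 to compound 2 cannot be sized because of the limit of > 100 ug/mL in this assay, at which 2 of the 3 values shown sit. For compound 3 this assay reports "not determined" (no result reported), so compound 3 stands without a number of its own. Compound 4 differs from compound 3 by chloro in place of methoxy on an aromatic carbon. For the measured compounds named here, no measured step bears on this change, and the one step known is unreadable, so no size or direction of step in this assay can be drawn from it. Compound 4 is therefore expected to give about 100 ug/mL, between 50 ug/mL and 200 ug/mL.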

Compound 4, half-maximal inhibitory concentration: > 100 ug/mL
Compound 4: no number, only a limit; the forecaster's own chance of this, stated with the estimate: 70%; the middle value sits exactly at the limit.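

The steps from compound 1 and from compound 2 to compound 4 cannot be read in this assay, since all three compounds give only a limit: the limit of > 100 ug/mL in this assay, at which 3 of the 4 values shown sit. On these data alone, whether chloro, methyl or hydrogen on an aromatic carbon makes any difference in this assay stays open, and so does where compound 3 stands.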